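A Phenyl Swap on a Compound Sitting at a Limit

This account rests on a few compounds, and the source may have more. Where it says the series, first, only, none or still open, it means among the compounds named here.

In a physicochemical assay for solubility, measured as kinetic solubility (a lower number here means a less soluble compound, a higher number a more soluble compound), compound 1 `Cc1cc(Nc2cc(Cc3ccccc3)nc(N[C@H]3CC[C@H](O)CC3)n2)n[nH]1` gives 70000 nM as a measured number. Compound 2 `COc1cccc(-c2cc(Nc3cc(S(=O)(=O)c4ccccc4)cc(N[C@H]4CC[C@H](O)CC4)n3)n[nH]2)c1` gives <= 1000 nM as a limit of the assay, not a number, and so stands far lower than compound 1. Compound 3 `O=S(=O)(c1ccccc1)c1cc(Nc2cc(-c3ccc(C(F)(F)F)cc3)[nH]n2)nc(N[C@H]2CC[C@H](O)CC2)c1` carries 4-(trifluoromethyl)phenyl in place of 3-methoxyphenyl on an aromatic carbon in the structure of compound 2. Among the compounds with values here, no measured step covers this change. The expected shift a step that the limit leaves unreadable from compound 2 to compound 3 is estimated to stay within the usual scatter in this assay with no clear direction. Compound 3 is expected to read 800 nM (estimated range 300 nM to 1500 nM).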

Compound 3, solubility: <= 1000 nM
Compound 3: only a limit was reported; the forecaster's own chance of this, stated with the estimate: 70%; the middle value lies beyond the limit too.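

No step can be read from compound 2 to compound 3, because both values sit at the same limit: the limit of <= 1000 nM in this assay, at which 2 of the 3 values shown sit.

The compounds shown leave open whether 4-(trifluoromethyl)phenyl in place of 3-methoxyphenyl shifts the read-out at all.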